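Replacing the naphthalenyl group with fluorophenyl on a shared core

A few compounds are considered here, and "the series" means these few. Any claim that something is new, unique, unknown or untested is made for them only; others in the source may bear on it.

compound 1 `COc1ccc(-c2cn3ccnc3c(-c3ccc4ncn(C5CCCCC5)c4c3)n2)cc1` — 49.9%
compound 2 `c1ccc2c(-c3cn4ccnc4c(-c4ccc5ncn(C6CCCCC6)c5c4)n3)cccc2c1` — 7.84%

Of the compounds shown here, two have been measured in a functional assay on SF-268 cells (Homo sapiens) for inhibition, read by sulforhodamine B assay, with a stated time of 48 h, tested at 10 uM; on this read-out higher numbers stand for more inhibition at the one concentration tested (going by the name of the read-out) and lower numbers for less inhibition. In this assay compound 1 gives 49.9%, and compound 2 gives 7.84%. Among the measured compounds shown here, compound 2 stands lowest of the two numbers; the nearest compound is compound 1, and the only measured step, a number 42.1 percentage points lower from compound 1 to compound 2 (beyond the scatter), separates them.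

Compound 3 `Fc1ccc(-c2cn3ccnc3c(-c3ccc4ncn(C5CCCCC5)c4c3)n2)cc1` differs from compound 2 in one place: 4-fluorophenyl in place of naphthalen-1-yl on an aromatic carbon. For the measured compounds named here, the one step that bears on this change is the move from compound 1 to compound 2, which was large and downward when a single ring gave way to two fused rings at this position. Compound 3 returns to a single ring there, so the change is expected to run the other way: a large upward step, a number 32.2 percentage points higher from compound 2 to compound 3 (beyond the scatter), is estimated. Compound 3 is therefore expected to give about 40% in this assay, within a range of 15% to 65%.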

Compound 3, a percentage reported as inhibition, at one concentration (the size of the read-out at that concentration, not a potency): 10.7%
For compound 3 the middle estimate is 29.3 percentage points above the measured one; measured number outside the range, below it.
By their numbers in this assay, from the lowest: compounds 2 and 3 (each within the scatter of the next); then compound 1.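

In this assay, 4-fluorophenyl in place of naphthalen-1-yl gives a number 2.9 percentage points higher from compound 2 to compound 3 (within the scatter), so a single ring at this place does not by itself bring back the number seen with 4-methoxyphenyl. Fluoro in place of methoxy on that ring gives a number 39.2 percentage points lower from compound 1 to compound 3 (beyond the scatter), which shows that, among these three compounds, the large step follows the methoxy group and not the change from two rings to one. No measurement shown here bears on what lies behind this.

Still open, going by these compounds, is whether the number depends on methoxy alone or would also hold with another group at that place on the phenyl ring, such as hydroxy, ethoxy or dimethylamino. The compounds shown also leave open how a methoxy group would fare on the naphthalen-1-yl ring.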